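This account rests on a few compounds, and the source may have more. Where it says the series, first, only, none or still open, it means among the compounds named here.

Measured in an ADME assay on MRC5 cells (Homo sapiens) for inhibition, read by MTT assay, with a stated time of 72 h; a lower number here means a stronger inhibitor, a higher number a weaker inhibitor:

- compound 1 `O=C(OCCCCCCO)OCCc1ccc(O)c(O)c1`: > 50000 nM
- compound 2 `CCCCCCCCCCCCOC(=O)OCCc1ccc(OCc2ccccc2)c(OCc2ccccc2)c1`: "not determined" (no result reported)
- compound 3 `CCCCOC(=O)OCCc1ccc(O)c(O)c1`: "not determined" (no result reported)

Only one of these entries carries a reading. For compound 1 the result is a limit and not a number: > 50000 nM. The whole of the evidence amounts to this: the limit of > 50000 nM in this assay, at which 1 of the 3 values shown sits. Among the compounds with values here, compound 2 and compound 3 gave no result, so neither offers a comparison, and no step between measured compounds exists to serve as a guide.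

Compound 4 `CCCCCCCCCCCCCCOC(=O)OCCc1ccc(O)c(O)c1` has not yet been measured. It differs from compound 1 as follows: octyl in place of hydroxy on a saturated chain carbon, six bonds along the chain from an oxygen next to a carbonyl group.

Within the data shown here, with no measured step to draw on, the expectation is tentative. A modest move toward a lower number in this assay seems more likely than a large one, and a second result at the limit remains quite possible. The estimate corresponds to an expected change of an at least 1.7-fold lower number from compound 1 to compound 4 (0.25 log units; that floor lies within the scatter). For compound 4 the estimated value is 28000 nM, with an expected range from 8000 nM to 60000 nM.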

Compound 4, half-maximal inhibitory concentration: 9100 nM
Compound 4: middle estimate off by 3.1-fold (0.49 log units), on the high side, within the range that was stated.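

In this assay, octyl in place of hydroxy on a saturated chain carbon, six bonds along the chain from an oxygen next to a carbonyl group, gives an at least 5.4-fold lower number from compound 1 to compound 4 (0.73 log units; beyond the scatter), so this position can carry a change that moves the result off the limit and beyond the scatter. Compound 1 carries a limit and not a number, > 50000 nM. The step is therefore a floor and not a measured size, and one of its two ends is not a number: the limit of > 50000 nM in this assay, at which 1 of the 4 values shown sits.

The hydroxy leaves and the octyl enters in the same step, so these compounds cannot tell whether the lower number comes from losing the one or from gaining the other. Also open, on these data alone, is how an amine or a carboxylic acid in place of the hydroxy, or a longer chain than that of compound 4, would read in this assay.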